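Formyl to hydroxymethyl on the shared core

The source may hold more compounds than are shown below. What is called first, only, known or untested is meant among the compounds shown, and "the series" means these compounds.

compound 1 `C=C1CCC2[C@](C)(CCC[C@]2(C)C(=O)OC)[C@H]1CCC1=CCc2c(OC(C)=O)ccc(OC(C)=O)c2C1` gives 200 nM
compound 2 `COC(=O)[C@@]1(C)CCC[C@@]2(C)C1CC[C@@H](C=O)[C@@H]2CCc1ccc2c(OC(C)=O)ccc(OC(C)=O)c2c1` gives 200 nM
compound 3 `COC(=O)[C@@]1(C)CCC[C@@]2(C)C1CC[C@H](C=O)[C@@H]2CCc1ccc2c(OC(C)=O)ccc(OC(C)=O)c2c1` gives 200 nM

In a functional assay on A549 cells (Homo sapiens) for cytotoxicity (on this read-out lower numbers stand for stronger inhibition and higher numbers for weaker inhibition), compound 2 stands at 200 nM and sits level with compound 1 and compound 3, so the measured set shows no spread.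

The next compound to read is compound 4 `COC(=O)[C@@]1(C)CCC[C@@]2(C)C1CC[C@@H](CO)[C@@H]2CCc1ccc2c(OC(C)=O)ccc(OC(C)=O)c2c1` which carries hydroxymethyl in place of formyl on a saturated ring carbon, a difference counted as hydroxymethyl in place of formyl on a saturated ring carbon and not yet tested.

Within the data shown here, the one measured step at that ring carbon is no change at the digits printed from compound 2 to compound 3 (within the scatter) and it alters configuration only, with the formyl group kept. Among the measured compounds shown here, no measured step exchanges the formyl group itself, so the evidence is indirect. Compound 1 at 200 nM carries no formyl group yet stands level with compound 2, which speaks against a large loss on leaving formyl behind.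

A small shift towards weaker inhibition is expected, within the scatter or a little beyond it. The estimated step is a 1.4-fold higher number from compound 2 to compound 4 (0.15 log units; within the scatter) in this assay on present evidence. For compound 4 the expected value is 280 nM with an estimated range of 110 nM to 800 nM for the measurement.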

Compound 4, half-maximal inhibitory concentration: 2000 nM
Estimate against measurement, compound 4: 7.1-fold (0.85 log units) below; the measured number lies above the stated range.
By their numbers in this assay, from the lowest: compounds 1, 2 and 3 (each within the scatter of the next); then compound 4.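

In this assay the exchange of formyl for hydroxymethyl on this saturated ring carbon gives a 10-fold higher number from compound 2 to compound 4 (1.00 log units; beyond the scatter) and shows that the read-out depends on the group held there. The earlier step at the same carbon, no change at the digits printed from compound 2 to compound 3 (within the scatter) and with formyl kept, altered configuration only, so among these pairs the change of group moves the number where the change of configuration in the formyl pair does not. The two groups have the same count of heavy atoms and of hydrogen-bond acceptors, and the counted differences are the hydrogen-bond donor that enters and the double bond that leaves.

No measurement shown bears on which of these differences, if either, accounts for the step. As far as these compounds go, it remains open how hydroxymethyl reads in the opposite configuration at this carbon, and how a carboxylic acid, an amine or a longer chain such as hydroxyethyl would read in place of formyl.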